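Amide-side variation on a trimethoxyphenyl acetanilide series

The source may report more compounds than this note shows. Statements on the series, on what has been measured and on what is new or still open speak of the compounds shown alone.

Compound 1 `COc1ccc(CN(C(C)=O)c2cc(OC)c(OC)c(OC)c2)cc1O` gives 79 nM in a functional assay on MGC-803 cells (Homo sapiens) for inhibition, read by MTT assay, with a stated time of 48 h; on this read-out higher numbers stand for weaker inhibition and lower numbers for stronger inhibition. Compound 2 `C=C(C)C(=O)N(Cc1ccc(OC)c(O)c1)c1cc(OC)c(OC)c(OC)c1` gives 390 nM in this assay, and compound 3 `COc1ccc(CN(C(=O)CO)c2cc(OC)c(OC)c(OC)c2)cc1O` gives 160 nM. Compound 3 thus holds the second highest of the three numbers, with compound 1 as its nearest neighbour and compound 2 as the furthest. The step from compound 3 to compound 4 `COc1ccc(CN(C(=O)C(C)C)c2cc(OC)c(OC)c(OC)c2)cc1O` replaces (isopropyl in place of hydroxymethyl on a carbonyl carbon). Among the compounds with values here, two measured steps bear on it: a 2.0-fold higher number from compound 1 to compound 3 (0.31 log units; beyond the scatter), which shows that adding the hydroxy costs a modest amount, so its removal should recover roughly that much; and a 2.4-fold lower number from compound 2 to compound 3 (0.39 log units; beyond the scatter), which shows that a branched three-carbon group on the carbonyl carbon sits higher than the hydroxymethyl. Isopropyl is both the hydroxy-free group and a branched three-carbon group, so these pull in opposite directions. A step close to the scatter in this assay is therefore expected for compound 4, a 1.3-fold higher number from compound 3 to compound 4 (0.10 log units; within the scatter), with the direction uncertain. Compound 4 is expected to give about 200 nM, within 70 nM to 600 nM.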

Compound 4, half-maximal inhibitory concentration: 210 nM
Compound 4: the middle estimate sits 1.1-fold (0.02 log units) below what was measured; the range from low to high includes it.
By their numbers in this assay, from the lowest: compound 1; then compounds 3, 4 and 2 (each within the scatter of the next, the first and the last beyond it).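

Hydroxymethyl and isopropyl on this carbonyl carbon cannot be told apart (a 1.3-fold higher number from compound 3 to compound 4 (0.12 log units; within the scatter)), and the same holds for isopropyl and 1-methylethenyl (a 1.9-fold lower number from compound 2 to compound 4 (0.27 log units; within the scatter)), so dropping the hydroxy does not bring the number back towards that of compound 1. Methyl remains separate from isopropyl (a 2.7-fold higher number from compound 1 to compound 4 (0.42 log units; beyond the scatter)), and among the four compounds shown, each of the other three groups gives a number above that of compound 1, with none going against this. No measurement at hand accounts for this separation.

From the compounds shown here alone, it remains open whether an aminomethyl group, a carboxylic acid or a longer straight chain on this carbonyl carbon would fall with these three groups or nearer to methyl. Whether any group here would give a number below that of compound 1 is also unsettled.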